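A few compounds are considered here, and "the series" means these few. Any claim that something is new, unique, unknown or untested is made for them only; others in the source may bear on it.

For the measured compounds named here, compound 1 `CNc1nc(NCc2ccc(C(=O)Nc3ccc(F)cc3)cc2)c2ccccc2n1` is one of three compounds measured in a functional assay on SW480 cells (Homo sapiens) for inhibition, read by luminescence and resazurin assay, with a stated time of 3 days (a lower number here means a stronger inhibitor, a higher number a weaker inhibitor), where compound 1 gives 4100 nM. That is the highest of the three numbers. Compound 2 `CNc1nc(NCc2ccc(NC(=O)c3ccc(F)cc3)cc2)c2ccccc2n1` gives 2000 nM in this assay, and the step of a 2.1-fold lower number from compound 1 to compound 2 (0.31 log units; beyond the scatter) lies beyond the usual scatter. Going by the values given here, compound 3 `Cc1ccc2nc(N3CCNC(C)C3)nc(NCc3ccc(C(=O)NCc4ccc(F)cc4)cc3)c2c1` gives 1400 nM in this assay, a lower number than that of compound 1, though no single-point step joins the two.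

Compound 4 `CCCCNc1nc(NCc2ccc(C(=O)Nc3ccc(F)cc3)cc2)c2ccccc2n1` is not yet measured. It differs from compound 1 by propyl in place of hydrogen on a saturated chain carbon bound to a nitrogen on an aromatic ring; read one bond further out, the change is methyl to butyl, or methylamino to butylamino. Among the compounds with values here, none of the measured steps bears on this position: the only single-point step among the measured compounds is a 2.1-fold lower number from compound 1 to compound 2 (0.31 log units; beyond the scatter), which swaps the carboxamide for the reversed amide on the aromatic carbon and leaves the methylamino group untouched. Within the data shown here, there is therefore no measured precedent for lengthening the chain on the nitrogen on the aromatic ring, and no step beyond the scatter is expected in this assay from that change alone.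

Compound 4 is accordingly estimated at 4000 nM in this assay, with a range from 1400 nM to 11000 nM, which means an expected step of a 1.0-fold lower number from compound 1 to compound 4 (0.01 log units; within the scatter).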

Compound 4, half-maximal inhibitory concentration: 1000 nM
The estimate for compound 4 lay 4.0-fold (0.60 log units) above the measured number; measured number below the stated range.
By their numbers in this assay, from the lowest: compounds 4, 3 and 2 (each within the scatter of the next); then compound 1.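

In this assay, the methylamino group of compound 1 proves not to be a silent position: butylamino in its place gives a 4.1-fold lower number from compound 1 to compound 4 (0.61 log units; beyond the scatter), a modest step, but one beyond the scatter. For the compounds shown here, the only single-point step among the earlier compounds changed the amide on the aromatic carbon, so this is the first sign that the chain on the nitrogen on the aromatic ring bears on the number, and here propyl in place of hydrogen goes with a stronger inhibitor rather than a weaker one. Nothing available accounts for this step, which stands as an observation only.

A single pair gives two chain lengths and no more, so the compounds shown leave open how an ethyl or propyl chain, a longer chain such as hexyl, or a branched chain such as isobutyl would read at this position, and whether a terminal amine or hydroxyl on the chain would change the number. They also leave open whether butylamino would bring a similar step on the reversed amide of compound 2.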